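This account rests on a few compounds, and the source may have more. Where it says the series, first, only, none or still open, it means among the compounds named here.

Of the compounds shown here, two of the same sulfonamide family have been tested in a functional assay on MDA-MB-231 cells (Homo sapiens) for antiproliferative activity, read by fluorescence and SYBR Green assay, with a stated time of 24 h; a higher number here means a weaker inhibitor, a lower number a stronger inhibitor. Compound 1, with the structure `Cc1ccc2c(c1)CCCN2S(=O)(=O)c1ccc(N2CCCC2=O)cc1`, gives 17 nM. Compound 2, with the structure `O=S(=O)(c1ccc(-n2cncn2)cc1)N1CCCc2ccccc21`, gives only a limit of the assay, > 5000 nM, so its true value is not known beyond that boundary. This matches (the limit of > 5000 nM in this assay, at which 1 of the 2 values shown sits), and compound 2 therefore stands at the weak end of what is shown, without a number of its own.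

The unmeasured compound 3, with the structure `O=C1CCCN1c1ccc(S(=O)(=O)N2CCCc3ccccc32)cc1`, arises from compound 2 by one change: 2-oxopyrrolidin-1-yl in place of 1H-1,2,4-triazol-1-yl on an aromatic carbon. Within the data shown here, no measured step of this kind exists here, so the expected size rests on the fact that compound 1, which also carries the 2-oxopyrrolidin-1-yl group, gives 17 nM. On that basis a large step downward in this assay, well beyond the usual scatter, is expected from compound 2 to compound 3, namely an at least 120-fold lower number from compound 2 to compound 3 (2.09 log units; beyond the scatter). Compound 3 is therefore estimated at 40 nM, with a likely range from 10 nM to 250 nM.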

Compound 3, half-maximal inhibitory concentration: 15 nM
Estimate against measurement, compound 3: 2.7-fold (0.43 log units) above; the measured number falls inside the stated range.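

On an aromatic carbon para to a large group, 2-oxopyrrolidin-1-yl in place of 1H-1,2,4-triazol-1-yl gives an at least 330-fold lower number from compound 2 to compound 3 (2.52 log units; beyond the scatter), so on an otherwise unchanged core this single group decides whether a clear number appears in this assay. That size is only a minimum, because compound 2 is held at a limit of the assay and has no number of its own: the limit of > 5000 nM in this assay, at which 1 of the 3 values shown sits.

Hydrogen in place of methyl on an aromatic carbon gives a 1.1-fold lower number from compound 1 to compound 3 (0.05 log units; within the scatter), so this methyl group makes no difference that can be told apart here, and the gap between compound 1 and compound 2, which differ in two places, can now be laid on the group that changes in the step above rather than on the methyl group.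

A single pair cannot separate the part played by the carbonyl from that of the ring itself, and a six-membered piperidin-2-one, an open acetamide group or a plain pyrrolidine would bear on that question. Going by these compounds, it also stays open whether the place of the methyl group accepts anything else, such as a chlorine atom or a methoxy group.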